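The source may hold more compounds than are shown below. What is called first, only, known or untested is meant among the compounds shown, and "the series" means these compounds.

Series notes. The three measured compounds share one core: compound 1 `CC1(C)c2[nH]nc(NC(=O)c3ccccc3)c2CN1Cc1cccc(Br)c1`, compound 2 `CC1(C)c2[nH]nc(NC(=O)c3ccccc3)c2CN1Cc1ccccc1F` and compound 3 `CC1(C)c2[nH]nc(NC(=O)c3ccccc3)c2CN1Cc1ccc(F)cc1F` differ only in the group on the saturated chain carbon bound to the amine nitrogen in the ring. In an assay on Sf21 cells for inhibition of high affinity nerve growth factor receptor (Homo sapiens), read by HTRF, with a stated time of 30 min, in the presence of a further agent that is not named here (on this read-out higher numbers stand for weaker inhibition and lower numbers for stronger inhibition), compound 1 gives 940 nM, compound 2 gives 450 nM and compound 3 gives 2320 nM. Compound 2 holds the lowest number of the three, and its gaps to compound 1 and to compound 3 are both beyond the scatter. Compound 4 `Cc1ccc(CN2Cc3c(NC(=O)c4ccccc4)n[nH]c3C2(C)C)cc1F` is not yet measured; its change from compound 2 is 3-fluoro-4-methylphenyl in place of 2-fluorophenyl on a saturated chain carbon bound to an amine nitrogen in a ring. The measured steps that bear on it are a 2.1-fold lower number from compound 1 to compound 2 (0.32 log units; beyond the scatter), a 2.5-fold higher number from compound 1 to compound 3 (0.39 log units; beyond the scatter) and a 5.2-fold higher number from compound 2 to compound 3 (0.71 log units; beyond the scatter): every departure from 2-fluorophenyl seen so far has carried a modest rise, and adding a fluoro to that ring raised the number as well. For compound 4 a modest rise is therefore expected, a 2.2-fold higher number from compound 2 to compound 4 (0.35 log units; beyond the scatter). The estimate for compound 4 in this assay is 1000 nM, with a range of 350 nM to 3000 nM.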

Compound 4, half-maximal inhibitory concentration: 940 nM
Estimate against measurement, compound 4: 1.1-fold (0.03 log units) above, within the range that was stated.
By their numbers in this assay, from the lowest: compound 2; then compounds 1 and 4 (each within the scatter of the next); then compound 3.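

Against 2-fluorophenyl, the methyl-bearing 3-fluoro-4-methylphenyl gives a 2.1-fold higher number from compound 2 to compound 4 (0.32 log units; beyond the scatter) in this assay and leaves compound 2 with the lowest number of the four, the third departure from that group to carry a rise. Two substituents on the ring do not fix the outcome: a 2.5-fold lower number from compound 3 to compound 4 (0.39 log units; beyond the scatter) separates two disubstituted phenyl groups, while no change at the digits printed from compound 1 to compound 4 (within the scatter) shows 3-fluoro-4-methylphenyl and 3-bromophenyl reading alike despite their different substituents. Nothing available accounts for these differences.

On these data alone, the comparison so far covers substituted phenyl groups only, and it remains open how unsubstituted phenyl, a pyridine or a methoxyphenyl would read on this saturated chain carbon. As far as these compounds go, whether a single fluoro elsewhere on the ring would match 2-fluorophenyl also remains open.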